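The source may report more compounds than this note shows. Statements on the series, on what has been measured and on what is new or still open speak of the compounds shown alone.

Measured compounds:
compound 1, `COc1cc(-c2cc(COCc3cn(Cc4cc(-c5ccccc5)cnc4Cl)nn3)on2)cc(OC)c1OC` — 43100 nM
compound 2, `COc1cc(-c2cc(COCc3cn(Cc4cc(-c5ccc(C)cc5)cnc4Cl)nn3)on2)cc(OC)c1OC` — 35300 nM
compound 3, `COc1cc(COCc2cn(Cc3cc(-c4ccc(C)cc4)cnc3Cl)nn2)cc(OC)c1OC` — 28600 nM

In a functional assay on HeLa cells (Homo sapiens) for cytotoxicity, read by MTT assay, with a stated time of 48 h (a lower number here means a stronger inhibitor, a higher number a weaker inhibitor), compound 1 gives 43100 nM, compound 2 gives 35300 nM, and compound 3 gives 28600 nM. Compound 3 stands lowest of the three numbers, yet its gaps to compound 2 and to compound 1 both lie within the scatter, so no order among the three can be read from these values.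

Compounds 1 and 2 differ in one place: hydrogen in place of methyl on an aromatic carbon. The step this change made is a 1.2-fold higher number from compound 2 to compound 1 (0.09 log units; within the scatter), a difference that sits within the scatter of repeated measurements.

Compound 4, `COc1cc(COCc2cn(Cc3cc(-c4ccccc4)cnc3Cl)nn2)cc(OC)c1OC`, is not yet measured. It differs from compound 3 in the same kind of change: hydrogen in place of methyl on an aromatic carbon. Compounds 3 and 2 share a large part of their structure, but the difference between the two cores is not broken down here.

The expectation for compound 4 rests on what the same change did between compounds 2 and 1. Because a 1.2-fold higher number from compound 2 to compound 1 (0.09 log units; within the scatter) was a small step within the scatter, the step of a 1.2-fold higher number from compound 3 to compound 4 (0.08 log units; within the scatter) is expected to be of similar size in this assay. Compound 4 is therefore estimated to give 34000 nM in this assay, with the expected range running from 17000 nM to 70000 nM.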

Compound 4, half-maximal inhibitory concentration: 41900 nM
Estimate against measurement, compound 4: 1.2-fold (0.09 log units) below; the measured number falls inside the stated range.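

In this assay, the change from 4-methylphenyl to phenyl gives a 1.5-fold higher number from compound 3 to compound 4 (0.17 log units; within the scatter) and so stays within the scatter, as it did on the core of compound 1. Set side by side, the two steps made by this one change on the two cores cannot be told apart: the same change on two cores in this assay, a 1.2-fold higher number (0.09 log units; within the scatter) from compound 2 to compound 1 and a 1.5-fold higher number (0.17 log units; within the scatter) from compound 3 to compound 4, 1.2-fold (0.08 log units) apart, within the scatter of two such steps. This shows that, across these two pairs, the change carries from one core to the other as a step too small to separate from repeated-measurement scatter, but it does not show that replacing methyl with hydrogen has a real effect in either pair, that the two steps share a true direction, or that the same would hold on any further core.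

The compounds shown carry only methyl or hydrogen at this place on the six-membered aromatic ring, which leaves open what an amine, a carboxylic acid or a longer chain such as propyl would do there. From the compounds shown here alone, with just two pairs, and all four numbers coming from this assay alone, it also remains open whether a larger step could appear with such groups, and whether it would then carry between the two cores.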